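This account rests on a few compounds, and the source may have more. Where it says the series, first, only, none or still open, it means among the compounds named here.

In a functional assay on MCF7 cells (Homo sapiens) for antiproliferative activity, read by MTT assay, with a stated time of 24 h (a lower number here means a stronger inhibitor, a higher number a weaker inhibitor), the measured compounds give these values:
- Compound 1 `CCn1c(C(=O)NCCO)ccc1C(CC)(CC)c1ccc(OCS(=O)(=O)c2ccccc2)c(C)c1` gives 15500 nM
- Compound 2 `CCn1c(C(=O)N[C@H](CO)CCO)ccc1C(CC)(CC)c1ccc(OCS(=O)(=O)c2ccccc2)c(C)c1` gives 28500 nM
- Compound 3 `CCn1c(C(=O)N[C@@H](CO)CCCO)ccc1C(CC)(CC)c1ccc(OCS(=O)(=O)c2ccccc2)c(C)c1` gives 29600 nM

Compound 3 at 29600 nM stands level with the other two, as a 1.9-fold higher number from compound 1 to compound 3 (0.28 log units; within the scatter) and a 1.0-fold higher number from compound 2 to compound 3 (0.02 log units; within the scatter) both lie within the scatter. For the measured compounds named here, compound 4 `CCn1c(C(=O)N[C@H](C)C(=O)O)ccc1C(CC)(CC)c1ccc(OCS(=O)(=O)c2ccccc2)c(C)c1` changes one place, on an amide-type nitrogen: a group of 5 heavy atoms (3 carbon, 2 oxygen; no ring) in place of a group of 7 heavy atoms (5 carbon, 2 oxygen; no ring), on an amide-type nitrogen and the 1-carboxyethyl group that enters appears in no measured compound. The closest evidence is the other changes at that part of the molecule. Like those two steps, a 1.8-fold higher number from compound 1 to compound 2 (0.26 log units; within the scatter) stayed within the scatter. These steps involve only 2-hydroxyethyl and 3-hydroxypropyl groups, so they offer a loose guide to the new group. No step beyond the scatter is therefore expected in this assay for this change. The expected size, as an estimate, is a 1.2-fold lower number from compound 3 to compound 4 (0.07 log units; within the scatter) and it carries real uncertainty. The estimate for compound 4 is 25000 nM with an expected range of 10000 nM to 60000 nM for now.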

Compound 4, half-maximal inhibitory concentration: > 50000 nM
Compound 4: no number, only a limit; the forecaster's own chance of this, stated with the estimate: 10%; middle value at least 2.0-fold (0.30 log units) from the limit.
By their numbers in this assay, from the lowest: compounds 1, 2 and 3 (each within the scatter of the next). At a limit, above all of these: compound 4.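

In this assay compound 4 gives > 50000 nM, which is a limit of the assay and not a number. For the compounds shown here, the chains on the amide-type nitrogen in compound 1, compound 2 and compound 3 stayed within the scatter of one another, whereas 1-carboxyethyl gives the first step at this place that lies beyond it: an at least 3.2-fold higher number from compound 1 to compound 4 (0.50 log units; beyond the scatter). The other two steps, an at least 1.6-fold higher number from compound 3 to compound 4 (0.22 log units; that floor lies within the scatter) and an at least 1.7-fold higher number from compound 2 to compound 4 (0.24 log units; that floor lies within the scatter), have floors within the scatter, so their true size remains unsettled.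

The 1-carboxyethyl group brings a carboxylic acid and a methyl branch together, and the compounds shown do not separate the two. On these data alone, whether an amine or a methyl ester at this place would behave like 2-hydroxyethyl or like 1-carboxyethyl also remains open.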